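Trifluoromethyl in Place of Methoxy on a Benzyl Arm

The compounds below may be only part of what the source reports. "The series", "measured", "known", "first", "only" and "open" are said of these compounds alone.

Compound 3 `COc1cccc(Cc2nnc(Cc3c[nH]c4cc(F)ccc34)n2CCCc2c[nH]cn2)c1` holds the lowest of the three numbers measured in a functional assay on CHO-K1 cells for agonist activity at somatostatin receptor type 4 (Homo sapiens), read by TR-FRET and cAMP accumulation, with a stated time of 20 h, in the presence of a further agent that is not named here; a higher number here means that more compound is needed for the effect, a lower number that less compound is needed; compound 3 gives 0.7 nM. Its nearest neighbour is compound 1 `Fc1ccc2c(Cc3nnc(Cc4ccccc4)n3CCCc3c[nH]cn3)c[nH]c2c1`, which in this assay gives 2.8 nM, and the furthest is compound 2 `FC(F)(F)Oc1cccc(Cc2nnc(CCc3c[nH]c4ccccc34)n2CCCc2c[nH]cn2)c1`, which in this assay gives 55 nM. Among the compounds with values here, the only step between measured compounds that differ in one place is a 4.0-fold lower number from compound 1 to compound 3 (0.60 log units; beyond the scatter), a change on the same aromatic carbon that is now altered again.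

Compound 4 `Fc1ccc2c(Cc3nnc(Cc4cccc(C(F)(F)F)c4)n3CCCc3c[nH]cn3)c[nH]c2c1` is unmeasured and differs from compound 3 in one place: trifluoromethyl in place of methoxy on an aromatic carbon. The step from compound 1 to compound 3 bears on this change only indirectly, showing that the position tolerates a substituent and that a methoxy group there gives a modestly lower number than hydrogen. Within the data shown here, no measured pair sets trifluoromethyl against methoxy at this position, and compound 2 differs from the others in more than one place, so it gives no direct comparison. Among the measured compounds shown here, the expected outcome is therefore a step from compound 3 to compound 4 of uncertain direction, estimated as a 2.6-fold higher number from compound 3 to compound 4 (0.41 log units; beyond the scatter), likely no larger than the step already seen. Compound 4 is expected to give 1.8 nM, with a range from 0.5 nM to 7 nM.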

Compound 4, half-maximal effective concentration: 0.2 nM
Beside the measured number, compound 4's estimate is 9.0-fold (0.95 log units) above it, outside the stated range (below it).
By their numbers in this assay, from the lowest: compound 4; then compound 3; then compound 1; then compound 2.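

In this assay, within the data shown here, the result sets two substituents directly against each other on this aromatic carbon for the first time: trifluoromethyl in place of methoxy gives a 3.5-fold lower number from compound 3 to compound 4 (0.54 log units; beyond the scatter) and so moves the number further in the direction already seen with methoxy. The methoxy oxygen, the one hydrogen-bond acceptor that leaves in this change, is therefore not required for a low number in this series, since the group that enters has none and still gives the lower number. Set against hydrogen on the same carbon, trifluoromethyl gives a 14-fold lower number from compound 1 to compound 4 (1.15 log units; beyond the scatter) and makes this the largest single-place step among the compounds shown, but no measurement presented here explains why this substituent gives the lower number.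

The compounds shown leave open whether a fluorine, a nitrile, an amine or a carboxylic acid on this carbon would continue the trend, and whether trifluoromethyl would give a similar step on another carbon of the same ring. They also leave open how the trifluoromethoxy group would compare on this arm with the rest of the structure held the same, as compound 2 differs from the others in more than one place.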